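A few compounds are considered here, and "the series" means these few. Any claim that something is new, unique, unknown or untested is made for them only; others in the source may bear on it.

Compound 3 `CC1=C(C(=O)Nc2ccc(F)cc2)C(c2ccc([N+](=O)[O-])cc2)N=C(SCc2ccccc2)N1` is measured in a functional assay on the whole organism (artery, strain albino) with Rattus norvegicus as the target, with a stated time of 15 min, at a dose of 10 mg/kg by the oral route (a higher number here means more inhibition at the dose given (going by the name of the read-out), a lower number less inhibition), at 3.1%. Compound 2 `COc1ccc(C2N=C(SCc3ccccc3Cl)NC(C)=C2C(=O)Nc2ccc(F)cc2)cc1OC` gives 2.6% in this assay, and compound 1 `COc1ccc(C2N=C(SCc3ccccc3)NC(C)=C2C(=O)Nc2ccc(F)cc2)cc1OC` gives 1.5%, so the three numbers cannot be told apart, each of the two steps to compound 3 falling within the scatter. Compound 4 `CC1=C(C(=O)Nc2ccc(F)cc2)C(c2ccc([N+](=O)[O-])cc2)N=C(SCc2ccccc2Cl)N1` differs from compound 3 by chloro in place of hydrogen on an aromatic carbon. That same change has been measured once already, giving a number 1.1 percentage points higher from compound 1 to compound 2 (within the scatter), a step within the scatter. The other measured step, a number 1.6 percentage points higher from compound 1 to compound 3 (within the scatter), concerns a different change and was likewise within the scatter. Compound 4 is therefore expected to show no step beyond the scatter: a number 0.9 percentage points higher from compound 3 to compound 4 (within the scatter). The estimated value of compound 4 in this assay is 4%, with a range from 0% to 10%.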

Compound 4, a percentage reported as inhibition, in the whole organism at one dose (the size of the read-out at that dose, not a potency): 1.5%
Compound 4: middle estimate off by 2.5 percentage points, on the high side; measured number inside the range.
By their numbers in this assay, from the lowest: compounds 1, 4, 2 and 3 (each within the scatter of the next).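

With the 4-nitrophenyl group in place, the change from benzylsulfanyl to (2-chlorobenzyl)sulfanyl gives a number 1.6 percentage points lower from compound 3 to compound 4 (within the scatter), and with the 2-chlorobenzyl group in place, 4-nitrophenyl for 3,4-dimethoxyphenyl gives a number 1.1 percentage points lower from compound 2 to compound 4 (within the scatter). The chloro change has now been read on two cores in this assay, and the two readings cannot be told apart: the same change on two cores in this assay, a number 1.1 percentage points higher (within the scatter) from compound 1 to compound 2 and a number 1.6 percentage points lower (within the scatter) from compound 3 to compound 4, 2.7 percentage points apart, within the scatter of two such steps The same holds for the swap on the saturated ring carbon: the same change on two cores in this assay, a number 1.6 percentage points higher (within the scatter) from compound 1 to compound 3 and a number 1.1 percentage points lower (within the scatter) from compound 2 to compound 4, 2.7 percentage points apart, within the scatter of two such steps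

Neither place has yet shown a step beyond the scatter. On these data alone, whether an amine or a carboxylic acid on the aromatic ring of the benzyl group, or a longer chain in place of benzyl, would give one remains open.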